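A few compounds are considered here, and "the series" means these few. Any claim that something is new, unique, unknown or untested is made for them only; others in the source may bear on it.

Compound 1, `Cc1ccc(CN2CCC(NC(=O)N(CC(=O)C(C)(C)O)Cc3ccc(-c4ccc(F)cc4)cc3)CC2)cc1`, gives 5.34 in an in vitro functional assay on HEK293 cells for antagonist activity at melanin-concentrating hormone receptor 1 (Homo sapiens), read by GTPgammaS binding, with a stated time of 45 min; a higher number here means a more potent compound, by a factor of ten per unit of this negative logarithm, a lower number a less potent compound. Compound 2, `Cc1ccc(CN2CCC(NC(=O)N(CC(=O)C(C)(C)O)Cc3ccc(-c4cccc(C#N)c4)cc3)CC2)cc1`, carries one change against compound 1, (3-cyanophenyl in place of 4-fluorophenyl on an aromatic carbon), and in this assay compound 2 gives 5.3, so that the step of a number 0.04 log units lower from compound 1 to compound 2 (within the scatter) stays within the scatter. Compound 3, `Cc1ccc(CN2CCC(CCN(Cc3ccc(-c4ccc(F)cc4)cc3)C(=O)NC(C)(C)CO)CC2)cc1`, rests on a different core; how its core differs from that of compound 1 is not broken down here. In this assay compound 3 gives 7.39, which is the highest of the three values and beyond the scatter above both compound 1 and compound 2.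

Compound 4, `Cc1ccc(CN2CCC(CCN(Cc3ccc(-c4cccc(C#N)c4)cc3)C(=O)NC(C)(C)CO)CC2)cc1`, is not yet measured. It stands to compound 3 as compound 2 stands to compound 1: the difference is 3-cyanophenyl in place of 4-fluorophenyl on an aromatic carbon, and the place is described in exactly the same words in both pairs, so this is the same change made on the second core. Because the earlier step was a number 0.04 log units lower from compound 1 to compound 2 (within the scatter), the step from compound 3 to compound 4 is expected to be small as well, a number 0.04 log units lower from compound 3 to compound 4 (within the scatter). Compound 4 is therefore estimated at 7.35, with a plausible span from 6.8 to 7.9.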

Compound 4, negative logarithm of the antagonist equilibrium constant: 7.08
Compound 4: the middle estimate sits 0.27 log units above what was measured; the measured number falls inside the stated range.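

Placing 3-cyanophenyl where 4-fluorophenyl stood on the second core gives, in this assay, a number 0.31 log units lower from compound 3 to compound 4 (beyond the scatter), a modest loss that is nonetheless larger than the usual scatter. Set beside the same change on the core of compound 1, this step cannot be told apart from the earlier one: the same change on two cores in this assay, a number 0.04 log units lower (within the scatter) from compound 1 to compound 2 and a number 0.31 log units lower (beyond the scatter) from compound 3 to compound 4, 0.27 log units apart, within the scatter of two such steps. Within these two pairs, the change therefore carries from one core to the other without a detectable difference in its effect, but two pairs show only that the data cannot separate the steps, not that they are identical or that the change would behave in the same way on any further core.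

The compounds shown leave open how an unsubstituted phenyl, or a phenyl bearing an amine or a carboxylic acid, would compare with these two groups on either core. They also leave open whether a step of this size would recur on a third core.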